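A few compounds are considered here, and "the series" means these few. Any claim that something is new, unique, unknown or untested is made for them only; others in the source may bear on it.

Measured compounds in a functional assay on HT-29 cells (Homo sapiens) for inhibition, read by MTT assay, with a stated time of 72 h; a higher number here means a weaker inhibitor of growth, a lower number a stronger inhibitor of growth:
compound 1, `N#C/C(=C\c1c(F)c(F)c(F)c(F)c1F)C(=O)c1ccc[nH]1`, gives 224000 nM
compound 2, `COc1ccc(CNC(=O)/C(C#N)=C/c2ccc(C)o2)cc1`, gives 92000 nM

Of these two numbers compound 2 holds the lower one, and its nearest neighbour, compound 1, lies beyond the usual scatter of repeated measurements, so compound 2 is the stronger growth inhibitor of the pair. Compound 3, `COc1ccc(CNC(=O)/C(C#N)=C/c2ccc(C)cc2)cc1`, is the next compound to be tested in this assay. It differs from compound 2 in a single place: 4-methylphenyl in place of 5-methylfuran-2-yl on a double-bonded chain carbon bound to a double-bonded chain carbon. Among the measured compounds shown here, no pair of measured compounds shows this exchange, and compounds 1 and 2 differ from each other in several places at once, so they give no direct guide to its effect. With nothing to point either way, the change is expected to move the number little, likely within the scatter, with a slight lean toward a weaker inhibitor. Compound 3 is therefore estimated at 120000 nM, with a plausible range from 40000 nM to 400000 nM, which means an expected step of a 1.3-fold higher number from compound 2 to compound 3 (0.12 log units; within the scatter).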

Compound 3, concentration for 50% growth inhibition: 36000 nM
Compound 3: middle estimate off by 3.3-fold (0.52 log units), on the high side; the measured number lies below the stated range.
By their numbers in this assay, from the lowest: compound 3; then compound 2; then compound 1.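

In this assay the exchange of 5-methylfuran-2-yl for 4-methylphenyl gives a 2.6-fold lower number from compound 2 to compound 3 (0.41 log units; beyond the scatter) and so shows that this position on the double-bonded chain carbon is sensitive to which aromatic group it carries. Here the six-membered ring of carbon only goes with the stronger growth inhibitor, though this rests on a single pair of compounds and a modest step. No measurement here gives a cause for this shift.

Going by these compounds, it remains open whether the ring itself or the methyl group on it matters more, and how an unsubstituted phenyl, a 4-methoxyphenyl or a pyridine ring would behave at this position. It is also unknown whether the same exchange would give a similar step on another core, such as that of compound 1.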